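The source may hold more compounds than are shown below. What is called first, only, known or untested is meant among the compounds shown, and "the series" means these compounds.

Compound 1 `Cc1ncncc1NC(=O)Nc1cnc(-n2nccn2)c(Cl)c1` and compound 2 `CC(C)c1ncncc1NC(=O)Nc1cnc(-n2nccn2)c(Cl)c1` share one core and differ only by isopropyl in place of methyl on an aromatic carbon. In a functional assay on OCI-Ly3 cells (Homo sapiens) for antiproliferative activity (on this read-out higher numbers stand for an effect only at larger amounts of compound and lower numbers for an effect already at smaller amounts), compound 1 gives only a limit of the assay, > 20000 nM. Compound 2 likewise gives only a limit in this assay, > 20000 nM. The step between them is a step that the two limits leave unreadable from compound 1 to compound 2, because the limit of > 20000 nM in this assay, at which 2 of the 3 values shown sit, leaves its size unreadable. Compound 3 `Cc1c(NC(=O)Nc2cnc(-n3nccn3)c(Cl)c2)cnc2ccccc12` is built on a different core; how the two cores differ is not broken down here. In this assay compound 3 gives 7170 nM. Compound 4 `CC(C)c1c(NC(=O)Nc2cnc(-n3nccn3)c(Cl)c2)cnc2ccccc12` is not yet measured and differs from compound 3 by isopropyl in place of methyl on an aromatic carbon. Among the measured compounds shown here, this is the same kind of change as the one from compound 1 to compound 2, not the same: in compound 3 the carbon is part of a fused or bridged system of two rings, ortho to a fused ring and meta to a fused ring, while in compound 1 it sits next to the ring nitrogen of a six-membered aromatic ring with 2 nitrogen. Because the measured step that the two limits leave unreadable from compound 1 to compound 2 gives no readable size, the step from compound 3 to compound 4 is expected to be small, a 1.0-fold lower number from compound 3 to compound 4 (0.01 log units; within the scatter). Compound 4 is therefore estimated at 7000 nM in this assay, between 2000 nM and 25000 nM.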

Compound 4, half-maximal effective concentration: 2420 nM
The estimate for compound 4 lay 2.9-fold (0.46 log units) above the measured number; the measured number falls inside the stated range.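

On the core of compound 3, isopropyl in place of methyl gives a 3.0-fold lower number from compound 3 to compound 4 (0.47 log units; beyond the scatter) in this assay, so on this core the larger group goes with an effect at smaller amounts of compound, though this is a modest step. The same change on the core of compound 1 cannot be read, because both compounds on that core stand at a limit of the assay rather than at a number: the limit of > 20000 nM in this assay, at which 2 of the 4 values shown sit. The series therefore shows this change working on one core only, and it neither confirms nor rules out that the change carries over from one core to the other.

Only methyl and isopropyl appear at this place, so two groups cannot tell whether the number would keep falling or turn back with a longer chain such as n-butyl. Going by these compounds, it also stays open what an amine or a carboxylic acid at the same carbon would do on the core of compound 3.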